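Swapping Chloro for Fluoro on the Aryl Ring

The source may report more compounds than this note shows. Statements on the series, on what has been measured and on what is new or still open speak of the compounds shown alone.

Of the compounds shown here, three built on one shared core have been measured in an assay on membranes from brain for binding affinity to adenosine receptor A1 (Rattus norvegicus), read by radioligand binding, tested at 20 uM; a lower number here means less inhibition, a higher number more inhibition at the concentration tested (going by the name of the read-out). Compound 1 `Cn1c(=O)[nH]c2c(cnn2-c2cc(Cl)ccc2Cl)c1=N` gives 1% in this assay. Compound 2 `CCCn1c(=O)[nH]c2c(cnn2-c2cccc(Cl)c2)c1=N` gives 68%. Compound 3 `Cn1c(=O)[nH]c2c(cnn2-c2cccc(Cl)c2)c1=N` gives 53%, the second highest of the three numbers: the change is a number 52 percentage points higher from compound 1 to compound 3 (beyond the scatter), and a number 15 percentage points lower from compound 2 to compound 3 (beyond the scatter). Compound 4 `Cn1c(=O)[nH]c2c(cnn2-c2cccc(F)c2)c1=N` has not yet been measured. It differs from compound 3 in one place: fluoro in place of chloro on an aromatic carbon. Neither measured step exchanges one halogen for another. Among the compounds with values here, the step from compound 1 to compound 3 removes a chloro outright, and the step from compound 2 to compound 3 shortens the chain on the aromatic nitrogen, so no step on record tests this exchange directly. With nothing closer to lean on, the expectation is a step of no more than modest size, possibly none beyond the scatter, a number 8 percentage points lower from compound 3 to compound 4 (within the scatter). Compound 4 is therefore estimated at about 45% in this assay, within a range from 20% to 70%.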

Compound 4, a percentage reported as inhibition, at one concentration (the size of the read-out at that concentration, not a potency): 44%
For compound 4 the middle estimate is 1 percentage points above the measured one, within the range that was stated.
By their numbers in this assay, from the lowest: compound 1; then compounds 4 and 3 (each within the scatter of the next); then compound 2.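

Fluoro in place of chloro on this aromatic carbon, meta to a large group, is the only exchange of one halogen for another among these compounds, and it gives a number 9 percentage points lower from compound 3 to compound 4 (within the scatter) in this assay. The earlier steps shown here changed the number of chloro groups or the length of the chain, whereas this one shows that, at this position, the two halogens cannot be told apart in this read-out. Nothing available bears on why the two compounds sit so close.

Going by these compounds, it remains open whether a methoxy group, an amine or a plain hydrogen on this carbon would keep the number near that of compound 3. On these data alone, it is also open whether the same exchange would give so small a step on the longer chain that compound 2 carries on the aromatic nitrogen.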